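This account rests on a few compounds, and the source may have more. Where it says the series, first, only, none or still open, it means among the compounds named here.

Compound 3 `CCOC(=O)CNC(=O)NCc1ccc(C(=O)N2CCCCc3ccccc32)cc1C` stands second highest of the three numbers in a functional assay on HEK293 cells for agonist activity at Vasopressin V2 receptor (Homo sapiens), read by a luciferase reporter and cAMP accumulation; on this read-out higher numbers stand for an effect only at larger amounts of compound and lower numbers for an effect already at smaller amounts: compound 3 gives 140 nM, while compound 2 `Cc1cc(C(=O)N2CCCCc3ccccc32)ccc1CNC(=O)NCC(=O)O` gives 180 nM and compound 1 `Cc1cc(C(=O)N2CCCCc3ccccc32)ccc1CNC(=O)Nc1ccccc1F` gives 30 nM. The unmeasured compound 4 `Cc1cc(C(=O)N2CCCCc3ccccc32)ccc1CNC(=O)NCC(=O)OC(C)C` differs from compound 3 by methyl in place of hydrogen on a saturated chain carbon bound to an oxygen next to a carbonyl group and a saturated chain carbon. The measured step that bears most on this is the change at the same oxygen, a 1.3-fold lower number from compound 2 to compound 3 (0.11 log units; within the scatter), which stayed within the scatter. The larger steps, a 6.0-fold higher number from compound 1 to compound 2 (0.78 log units; beyond the scatter) and a 4.7-fold higher number from compound 1 to compound 3 (0.67 log units; beyond the scatter), concern the replacement of the 2-fluorophenyl and do not touch this part of the molecule. Compound 4 is therefore expected to show only a 1.1-fold higher number from compound 3 to compound 4 (0.03 log units; within the scatter), within the usual scatter. Compound 4 is estimated at 150 nM, with a range from 70 nM to 330 nM.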

Compound 4, half-maximal effective concentration: 140 nM
Compound 4: middle estimate off by 1.1-fold (0.03 log units), on the high side, and the stated range covers the measured number.
By their numbers in this assay, from the lowest: compound 1; then compounds 3, 4 and 2 (each within the scatter of the next).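

Ethyl to isopropyl on this oxygen gives no change at the digits printed from compound 3 to compound 4 (within the scatter), so a methyl added at this saturated chain carbon is tolerated. With a 1.3-fold lower number from compound 2 to compound 4 (0.11 log units; within the scatter) as well, the carboxylic acid and its two esters all lie within the scatter of one another, and a 4.7-fold higher number from compound 1 to compound 4 (0.67 log units; beyond the scatter) shows that the isopropyl ester stays apart from the 2-fluorophenyl compound, as the ethyl ester did. No evidence is available that explains this flat ester series. Still open, going by these compounds, is whether a longer chain or a benzyl group on this oxygen, or a primary amide in place of the ester, would stay within the scatter.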